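The compounds below may be only part of what the source reports. "The series", "measured", "known", "first", "only" and "open" are said of these compounds alone.

Compound 1 `CC(=O)c1cc(C(=O)c2ccccc2)c(=O)[nH]c1C` was tested in an assay on isolated protein for inhibition of 3',5'-cyclic-AMP phosphodiesterase 4A (Cavia porcellus), read by cAMP accumulation, tested at 1 uM (on this read-out lower numbers stand for a weaker effect and higher numbers for a stronger effect at the one concentration tested), where compound 1 gives 0%. A second compound, compound 2 `O=C1CC(c2ccccc2)Cc2[nH]c(=O)c(S(=O)(=O)c3ccccc3)cc21`, gives 0% in this assay; the two readings are level at the digits shown, and the gap between them lies within the usual scatter of repeated measurements. Compound 1 thus stands beside compound 2 as a compound with no measurable effect at the single concentration tested. The unmeasured compound 3 `CC(=O)c1cc(C(=O)C(C)(C)C)c(=O)[nH]c1C` differs from compound 1 in one place: tert-butyl in place of phenyl on a carbonyl carbon. Among the measured compounds shown here, no step between measured compounds shows what this kind of exchange does in this assay, so nothing in the numbers points to a change in either direction. The step expected from compound 1 to compound 3 is none beyond the scatter, that is a number 2 percentage points higher from compound 1 to compound 3 (within the scatter). Compound 3 is therefore estimated to give 2% in this assay, within a range from -8% to 15%.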

Compound 3, a percentage reported as inhibition, at one concentration (the size of the read-out at that concentration, not a potency): 0%
Compound 3: middle estimate off by 2 percentage points, on the high side; low and high end bracket the measured number.
By their numbers in this assay, from the lowest: compounds 1, 2 and 3 (each within the scatter of the next).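

With tert-butyl in place of phenyl on a carbonyl carbon, this assay shows no change at the digits printed from compound 1 to compound 3 (within the scatter). Among the compounds shown here, this is the first exchange read at this position, and it shows that a six-membered aromatic ring of carbon is not needed there to keep the reading where it stands, although a step between two compounds with no measurable effect cannot show how the group would act in a compound that has one. Nothing available explains this flat result.

Still open, on these data alone, is whether a different group on this carbonyl carbon, such as an amine, a carboxylic acid or a longer chain, would give a reading beyond the scatter. Also open, as far as these compounds go, is whether any change to the shared core would give this exchange a measurable effect.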